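A few compounds are considered here, and "the series" means these few. Any claim that something is new, unique, unknown or untested is made for them only; others in the source may bear on it.

Measured compounds:
compound 1 `CN(C)CCCN1CCN(CC(=O)Nc2ccc(-c3nc4cc(F)ccc4o3)cc2)CC1` — in a functional assay on C6 cells (Rattus norvegicus) for cytotoxicity, read by MTT assay, with a stated time of 24 h (a higher number here means a weaker inhibitor, a lower number a stronger inhibitor), compound 1 gives 27500 nM
compound 2 `CN(C)CCN1CCN(CC(=O)Nc2ccc(-c3nc4cc(F)ccc4o3)cc2)CC1` — in this assay compound 2 gives 4390 nM
compound 3 `Cc1cc(-c2nc3cc(F)ccc3o2)ccc1NC(=O)CN1CCN(CCCN(C)C)CC1` — in this assay compound 3 gives 11800 nM

Compound 1 stands at the highest number of the three: a 2.3-fold lower number from compound 1 to compound 3 (0.37 log units; beyond the scatter) and a 6.3-fold lower number from compound 1 to compound 2 (0.80 log units; beyond the scatter) both run downward from it. Compound 4 `CN(C)CCCN1CCN(CC(=O)Nc2ccc(-c3nc4cc(Cl)ccc4o3)cc2)CC1` differs from compound 1 by chloro in place of fluoro on an aromatic carbon. Neither measured step bears on this change: the step from compound 1 to compound 2 alters the amine chain and the step from compound 1 to compound 3 adds a methyl elsewhere; no halogen swap has been measured in the series. With nothing to lean on, the expectation for compound 4 is a step within the scatter, a 1.3-fold lower number from compound 1 to compound 4 (0.10 log units; within the scatter), and the estimate is 22000 nM with a range from 8000 nM to 60000 nM.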

Compound 4, half-maximal inhibitory concentration: 910 nM
The estimate for compound 4 lay 24-fold (1.38 log units) above the measured number; the whole stated range lies above it.
By their numbers in this assay, from the lowest: compound 4; then compound 2; then compound 3; then compound 1.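

Replacing fluoro with chloro in the 5-fluoro-1,3-benzoxazol-2-yl group gives a 30-fold lower number from compound 1 to compound 4 (1.48 log units; beyond the scatter) in this assay and thus makes this aromatic carbon a sensitive point in the series. That single-atom change moves the number further than the amine chain change, a 6.3-fold lower number from compound 1 to compound 2 (0.80 log units; beyond the scatter) in the same assay, and further than the added methyl, a 2.3-fold lower number from compound 1 to compound 3 (0.37 log units; beyond the scatter) on the same scale. Nothing shown explains the size of the halogen step.

From the compounds shown here alone, whether bromo, methoxy or hydrogen at this carbon would lower the number as chloro does remains open. So does whether chloro has the same effect with the shorter chain of compound 2 or the added methyl of compound 3.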